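Shrinking the Ring on a Bombesin Receptor Agonist

The compounds below may be only part of what the source reports. "The series", "measured", "known", "first", "only" and "open" are said of these compounds alone.

Compound 1 `CC(C)(C)c1cnc(CCc2ccc(-c3ccccc3C(=O)O)cc2)[nH]1`: 2750 nM
Compound 2 `O=C(O)c1ccccc1-c1ccc(CCc2ncc(C3CCCCC3)[nH]2)cc1`: 14.7 nM

Among the measured compounds shown here, in an in vitro functional assay on cells for agonist activity at Bombesin receptor subtype-3 (Mus musculus), read by luminescence and calcium flux (a lower number here means that less compound is needed, a higher number that more compound is needed for the effect), compound 2 gives the lowest of the two numbers so far; its nearest neighbour is compound 1, and a 190-fold lower number from compound 1 to compound 2 (2.27 log units; beyond the scatter) separates them. Compound 3 `O=C(O)c1ccccc1-c1ccc(CCc2ncc(CC3CC3)[nH]2)cc1` differs from compound 2 by cyclopropylmethyl in place of cyclohexyl on an aromatic carbon. For the measured compounds named here, only that one measured step bears on this change, and it was large. Because a 190-fold lower number from compound 1 to compound 2 (2.27 log units; beyond the scatter) followed the arrival of a ring, and cyclopropylmethyl keeps a ring but a three-membered one, a number between those of the two measured compounds is expected. Compound 3 is expected to give about 200 nM, within 40 nM to 1500 nM. The expected step is a 14-fold higher number from compound 2 to compound 3 (1.13 log units; beyond the scatter).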

Compound 3, half-maximal effective concentration: 72 nM
Compound 3: the middle estimate sits 2.8-fold (0.44 log units) above what was measured; the measured number falls inside the stated range.
By their numbers in this assay, from the lowest: compound 2; then compound 3; then compound 1.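

In this assay a six-membered ring proves not to be required on this aromatic carbon: the three-membered ring of cyclopropylmethyl still brings a 38-fold lower number from compound 1 to compound 3 (1.58 log units; beyond the scatter) and gives up only a 4.9-fold higher number from compound 2 to compound 3 (0.69 log units; beyond the scatter) in return. Among the compounds shown here, both ring-bearing groups give lower numbers than tert-butyl, the one group here without a ring. Nothing measured here says why these groups differ.

Still open, going by these compounds, is whether the ring itself or the overall size of the group counts most. A cyclopentyl group, a cyclohexylmethyl group or an open longer chain on this carbon could help to separate the two.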